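Replacing a Nitro Group with a Hydroxycyclohexylamino Group

A few compounds are considered here, and "the series" means these few. Any claim that something is new, unique, unknown or untested is made for them only; others in the source may bear on it.

Of the compounds shown here, three have so far been measured in an assay for inhibition of Tryptophan 2,3-dioxygenase (Homo sapiens), with stated times of 10 min and 60 min; on this read-out lower numbers stand for stronger inhibition and higher numbers for weaker inhibition. Compound 1 `Oc1ccc(CNc2cc(C(F)(F)F)cc3[nH]ncc23)cc1` gives 2550 nM in this assay. Compound 2 `O=[N+]([O-])c1ccccc1CNc1cc(Br)cc2[nH]ncc12` gives 39000 nM. Compound 3 `O=[N+]([O-])c1cccc(CNc2cc(C(F)(F)F)cc3[nH]ncc23)c1` gives 5170 nM, which is the second highest of the three numbers. Its nearest neighbour is compound 1, with a lower number, and its furthest is compound 2, with a higher number; both of these differences lie beyond the usual scatter of repeated measurements, so compound 1 is a stronger inhibitor than compound 3 and compound 2 a weaker one.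

Compound 4 `OC1CCCC(Nc2cccc(CNc3cc(C(F)(F)F)cc4[nH]ncc34)c2)C1` has not yet been measured. It differs from compound 3 in one place: (3-hydroxycyclohexyl)amino in place of nitro on an aromatic carbon. Among the compounds with values here, no step between two measured compounds corresponds to this change, so the expectation must rest on the wider picture. Compound 1, which carries a hydroxy group rather than a nitro group on its outer ring, gives 2550 nM and thereby stands below compound 3, whose value is 5170 nM. On that basis a modest step toward a lower number is expected, that is a 2.6-fold lower number from compound 3 to compound 4 (0.41 log units; beyond the scatter). Compound 4 is accordingly estimated at 2000 nM, with a plausible range from 500 nM to 8000 nM.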

Compound 4, half-maximal inhibitory concentration: > 100000 nM
Compound 4 ended at the assay's limit (the forecaster's own chance of this, stated with the estimate: 5%); middle value at least 50-fold (1.69 log units) from the limit.
By their numbers in this assay, from the lowest: compound 1; then compound 3; then compound 2. At a limit, above all of these: compound 4.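

The step from nitro to (3-hydroxycyclohexyl)amino on this aromatic carbon, meta to a large group, is the first change in one place among these compounds, and it gives an at least 19-fold higher number from compound 3 to compound 4 (1.28 log units; beyond the scatter). This shows that the position does not accept every group: here, the larger group with its six-membered non-aromatic ring takes inhibition out of the range that can be read, and the change is large even though the core of compound 3 stays the same. In this assay compound 4 gives > 100000 nM, which is a limit of the assay and not a number, so the step has a known lower bound but no known size: the limit of > 100000 nM in this assay, at which 1 of the 4 values shown sits.

The compounds shown leave open which part of the entering group goes with this loss, since a plain amino group, a cyclohexylamino group without the hydroxy, or a methoxy group on the same aromatic carbon would each separate the ring, the nitrogen and the hydroxy from one another. They also leave open whether a group of intermediate size, such as a dimethylamino or a morpholine ring, would retain inhibition at this position.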